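The source may report more compounds than this note shows. Statements on the series, on what has been measured and on what is new or still open speak of the compounds shown alone.

Measured in an assay for inhibition of cathepsin S (Homo sapiens); on this read-out higher numbers stand for weaker inhibition and lower numbers for stronger inhibition:
- compound 1 `CC(C)C[C@H](NC(=O)N1CCOCC1)C(=O)NCC#N` gives 124 nM
- compound 2 `CC(C)C[C@H](NC(=O)N1CCOCC1)C(=O)N[C@@H](C)C#N` gives 142 nM
- compound 3 `CC(C)C[C@H](NC(=O)N1CCOCC1)C(=O)N[C@H](C#N)C(C)(C)C` gives 107000 nM

Compound 3 stands highest of the three numbers, far from both others: an 860-fold higher number from compound 1 to compound 3 (2.94 log units; beyond the scatter) and a 750-fold higher number from compound 2 to compound 3 (2.88 log units; beyond the scatter). Compounds 1 and 2 themselves sit together, since a 1.1-fold higher number from compound 1 to compound 2 (0.06 log units; within the scatter).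

The next compound is compound 4 `CC(C)C[C@H](NC(=O)N1CCOCC1)C(=O)N[C@H](C#N)COCc1ccccc1Cl`; the change is ((2-chlorobenzyl)oxy)methyl in place of tert-butyl on a saturated chain carbon bound to an amide-type nitrogen and a triple-bonded carbon. Going by the values given here, no measured step exchanges a tert-butyl for another group at this carbon, so no step bears directly on the move. What the measured steps show is that hydrogen and methyl at this carbon give similar numbers, while tert-butyl gives a number far higher. Compound 4 carries a group unlike tert-butyl in name and count, so the starting number of compound 3 is taken as an outlier among this trio rather than as a baseline, and a large step downward in this assay is expected: a 710-fold lower number from compound 3 to compound 4 (2.85 log units; beyond the scatter). Where compound 4 will land against compounds 1 and 2 cannot be read from these three numbers, so the range stays wide.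

Compound 4 is estimated at 150 nM, expected between 25 nM and 1500 nM.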

Compound 4, half-maximal inhibitory concentration: 9 nM
Compound 4: middle estimate off by 17-fold (1.22 log units), on the high side, and the stated range ends above it.
By their numbers in this assay, from the lowest: compound 4; then compounds 1 and 2 (each within the scatter of the next); then compound 3.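

At the saturated chain carbon bound to an amide-type nitrogen and a triple-bonded carbon, the very high number given by tert-butyl does not extend to every larger group: measured in this assay, ((2-chlorobenzyl)oxy)methyl in place of tert-butyl gives the largest step in the series (a 12000-fold lower number from compound 3 to compound 4 (4.08 log units; beyond the scatter)). The earlier compounds shown here showed this position only as flat between hydrogen and methyl or sharply worse with tert-butyl, whereas the new group also takes the number well under both of the small substituents (a 14-fold lower number from compound 1 to compound 4 (1.14 log units; beyond the scatter); a 16-fold lower number from compound 2 to compound 4 (1.20 log units; beyond the scatter)), so this carbon can carry a substituent that strengthens inhibition and compound 4 is the strongest of the four. The data give no measurement that would explain why tert-butyl and ((2-chlorobenzyl)oxy)methyl part so widely at this carbon.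

Which part of the entering group accounts for the gain stays open, whether the chlorine, the ether oxygen or the aromatic ring. Also open, from the compounds shown here alone, is how a benzyloxymethyl group without chlorine, or a plain butyl chain at this carbon, would compare with compound 4 in this assay.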